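The source may report more compounds than this note shows. Statements on the series, on what has been measured and on what is new or still open speak of the compounds shown alone.

- compound 1 `C=C1[C@@H](OC(C)=O)C[C@@H]2[C@](C)(CO[Si](C)(C)C(C)(C)C)[C@H](OC(C)=O)CC[C@@]2(C)[C@@H]1C[C@@H](Nc1ccccc1)C1=CCOC1=O`, 5710 nM
- compound 2 `C=C1[C@@H](OC(C)=O)C[C@@H]2[C@](C)(CO[Si](C)(C)C(C)(C)C)[C@H](OC(C)=O)CC[C@@]2(C)[C@@H]1C[C@@H](Nc1ccc(OC)cc1)C1=CCOC1=O`, 5630 nM

Only these two compounds have been measured in a functional assay on KB cells (Homo sapiens) for cytotoxicity, read by sulforhodamine B assay (on this read-out higher numbers stand for weaker inhibition and lower numbers for stronger inhibition), and they stand within the usual scatter of each other. Compound 2, at 5630 nM, therefore sits level with compound 1, and no order can be read between them.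

The next compound is compound 3 `C=C1[C@@H](OC(C)=O)C[C@@H]2[C@](C)(CO[Si](C)(C)C(C)(C)C)[C@H](OC(C)=O)CC[C@@]2(C)[C@@H]1C[C@@H](Nc1cccc(OC)c1)C1=CCOC1=O`. It differs from compound 2 as follows: 3-methoxyphenyl in place of 4-methoxyphenyl on an amine nitrogen. In words, this is 3-methoxyphenyl in place of 4-methoxyphenyl on an amine nitrogen.

Within the data shown here, one measured step bears on this change, and it is a 1.0-fold lower number from compound 1 to compound 2 (0.01 log units; within the scatter). That step is methoxy in place of hydrogen on an aromatic carbon, and it stays within the scatter. Among the measured compounds shown here, it is only a partial guide, since no measured compound carries 3-methoxyphenyl. Even so, it gives no reason to expect a real shift when the methoxy group is placed differently.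

The expected change is a 1.0-fold lower number from compound 2 to compound 3 (0.01 log units; within the scatter), which means none beyond the scatter in this assay. Compound 3 is expected at 5500 nM, with an estimated range of 3000 nM to 10000 nM.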

Compound 3, half-maximal inhibitory concentration: 45200 nM
For compound 3 the middle estimate is 8.2-fold (0.91 log units) below the measured one; measured number above the stated range.
By their numbers in this assay, from the lowest: compounds 2 and 1 (each within the scatter of the next); then compound 3.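

In this assay, the place of the methoxy group on the phenyl ring on the amine nitrogen matters, even though the atoms stay the same: 3-methoxyphenyl in place of 4-methoxyphenyl gives an 8.0-fold higher number from compound 2 to compound 3 (0.90 log units; beyond the scatter) and so weaker inhibition. The methoxy group therefore cannot be treated as a silent addition, as the first pair alone suggested: a 1.0-fold lower number from compound 1 to compound 2 (0.01 log units; within the scatter), yet placing the group as in compound 3 gives a 7.9-fold higher number from compound 1 to compound 3 (0.90 log units; beyond the scatter). No measurement offered here accounts for this difference.

The three compounds leave open whether the weakening belongs to methoxy itself or would also appear with another group carried the same way, such as a 3-chlorophenyl or 3-hydroxyphenyl on the amine nitrogen. They also leave open whether a larger group, such as 3-ethoxyphenyl, would weaken inhibition further or whether the effect stops at methoxy, and a single cell line cannot show whether the same gap appears in other cells.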